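The compounds below may be only part of what the source reports. "The series", "measured", "known", "first", "only" and "open" are said of these compounds alone.

For the measured compounds named here, compound 1 `COc1cccc(/C=C/C(=O)c2c(OC)cc(OC)cc2OC)c1` gives 3900 nM in a functional assay on Caco-2 cells (Homo sapiens) for cytotoxicity, with a stated time of 48 h (a lower number here means a stronger inhibitor, a higher number a weaker inhibitor), the lowest of the three numbers measured so far. Compound 2 `COc1cc(OC)c(C(=O)/C=C/c2ccc(Br)cc2)c(OC)c1` gives 6800 nM in this assay; the step of a 1.7-fold higher number from compound 1 to compound 2 (0.24 log units; within the scatter) puts 4-bromophenyl in place of 3-methoxyphenyl on a double-bonded chain carbon bound to a double-bonded chain carbon. Compound 3 `COc1cc(O)c(C(=O)/C=C/c2ccccc2SC)c(OC)c1` gives 9600 nM in this assay; it differs from compound 1 in more than one place, so its two values show only a gap beyond the scatter, with no single change to tie it to.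

Compound 4 `COc1cc(OC)c(C(=O)/C=C/c2ccccc2)c(OC)c1` is not yet measured. It differs from compound 1 in one place: hydrogen in place of methoxy on an aromatic carbon

Going by the values given here, the one measured step that bears on this change is a 1.7-fold higher number from compound 1 to compound 2 (0.24 log units; within the scatter), in which another group took the place of the same 3-methoxyphenyl and the number stayed within the scatter. Among the compounds with values here, no measured step shows the effect of removing the methoxy alone. On this basis the step from compound 1 to compound 4 is expected to stay within the scatter, with no direction to call; the expected step is a 1.2-fold higher number from compound 1 to compound 4 (0.06 log units; within the scatter). Compound 4 is therefore estimated at 4500 nM in this assay, with a range from 2000 nM to 10000 nM.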

Compound 4, half-maximal inhibitory concentration: 5800 nM
Compound 4: middle estimate off by 1.3-fold (0.11 log units), on the low side, and the stated range covers the measured number.
By their numbers in this assay, from the lowest: compounds 1, 4, 2 and 3 (each within the scatter of the next, the first and the last beyond it).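

Removing the methoxy from the aromatic carbon meta to a large group, which turns 3-methoxyphenyl into phenyl, gives a 1.5-fold higher number from compound 1 to compound 4 (0.17 log units; within the scatter) in this assay, so among the compounds shown this position does not need the methoxy for a number in this range. For the compounds shown here, compound 4 also supplies the plain phenyl comparison that the earlier compounds lacked: hydrogen in place of bromo gives a 1.2-fold lower number from compound 2 to compound 4 (0.07 log units; within the scatter), so among compounds 1, 2 and 4 neither methoxy nor bromo separates from hydrogen, and the earlier step between the two substituted compounds now has an unsubstituted partner on the same footing. No measurement on hand gives a reason for these readings.

Compound 3 differs from compound 4 in more than one place, so what its hydroxy on the shared core and its methylthio group each contribute cannot be separated. On these data alone, it also remains open whether this aromatic ring would tolerate an amine or a carboxylic acid as it tolerates methoxy and bromo, or whether such a group would take the number beyond the scatter.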